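Compound 4: acetoxy in place of sulfamoylamino

The compounds below may be only part of what the source reports. "The series", "measured", "known", "first", "only" and "open" are said of these compounds alone.

In an ADME assay on microsomes from liver (Homo sapiens) for metabolic stability, read by LC-MS, with NADPH named in the record, with a stated time of 60 min, tested at 1 uM, in the absence of a further agent (a lower number here means that less of the compound is left, a higher number that more of the compound is left), compound 1 (`CCCCCC(=O)N[C@@H]1CCN(c2cc(C)nn3c(-c4ccc(OC)c(OC)c4)c(C)nc23)C1`) gives > 95% as a limit, not a number. Compound 2 (`COc1ccc(-c2c(C)nc3c(N4CC[C@@H](NS(=O)(=O)C5CC5)C4)cc(C)nn23)cc1OC`) likewise gives > 95% as a limit. Compound 3 (`COc1ccc(-c2c(C)nc3c(N4CC[C@@H](NS(N)(=O)=O)C4)cc(C)nn23)cc1OC`) gives > 95% as a limit too. Compound 3 therefore stands on a shared limit (the limit of > 95% in this assay, at which 3 of the 3 values shown sit). Compound 4 (`COc1ccc(-c2c(C)nc3c(N4CC[C@@H](OC(C)=O)C4)cc(C)nn23)cc1OC`) has acetoxy in place of sulfamoylamino on a saturated ring carbon. The nearest measured steps (a step that the two limits leave unreadable from compound 1 to compound 2), (a step that the two limits leave unreadable from compound 1 to compound 3) and (a step that the two limits leave unreadable from compound 2 to compound 3) give no size, and none brings in acetoxy. Because compound 3 sits at > 95% as a limit, only a downward step could be read, so a modest fall in this assay is expected. The estimated change is (a number at least 13 percentage points lower from compound 3 to compound 4 (beyond the scatter)). For compound 4 the expected value is 82% (55% to 98%).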

Compound 4, percent of the compound remaining: > 95%
Compound 4: a limit, no number (the forecaster's own chance of this, stated with the estimate: 35%); at least 13 percentage points between middle value and limit.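

In this assay compound 4 sits at the same limit as compound 1, compound 2 and compound 3, so no step among these compounds can be read: the limit of > 95% in this assay, at which 4 of the 4 values shown sit.

Going by these compounds, whether acetoxy, sulfamoylamino, (cyclopropylsulfonyl)amino and (pentylcarbonyl)amino differ at all in percent of compound remaining stays open.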